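Predicting Compound 4 from a Repeated Substitution

This account rests on a few compounds, and the source may have more. Where it says the series, first, only, none or still open, it means among the compounds named here.

Measured compounds:
Compound 1, `COc1ccc(C2=NN(C(=O)c3cccnc3Cl)C(c3ccc(Br)cc3)C2)cc1`: 3050 nM
Compound 2, `COc1ccc(C2=NN(C(=O)c3ccc(C)nc3)C(c3ccc(Br)cc3)C2)cc1`: 4280 nM
Compound 3, `O=C(c1cccnc1Cl)N1N=C(c2ccc(Cl)cc2)CC1c1ccc(Cl)cc1`: 3580 nM

Three compounds have been examined in a functional assay on WM 266-4 cells (Homo sapiens) for antiproliferative activity, read by MTT assay, with a stated time of 24 h; on this read-out lower numbers stand for stronger inhibition of growth and higher numbers for weaker inhibition of growth. Compound 1 gives 3050 nM, compound 2 gives 4280 nM and compound 3 gives 3580 nM in this assay. All three numbers lie within the scatter of one another, so no order among them can be read from these data.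

Compound 1 and compound 2 differ by one change, (6-methylpyridin-3-yl in place of 2-chloropyridin-3-yl on a carbonyl carbon), and this change made a 1.4-fold higher number from compound 1 to compound 2 (0.15 log units; within the scatter). Compound 3 carries a different core from compound 1; the difference between the two cores is not broken down here.

Compound 4, `Cc1ccc(C(=O)N2N=C(c3ccc(Cl)cc3)CC2c2ccc(Cl)cc2)cn1`, has not yet been measured in this assay. It relates to compound 3 by 6-methylpyridin-3-yl in place of 2-chloropyridin-3-yl on a carbonyl carbon, which is the same change as that from compound 1 to compound 2, at the same place on the carbonyl carbon. Because the earlier instance of this change produced a 1.4-fold higher number from compound 1 to compound 2 (0.15 log units; within the scatter), a step of similar size is expected here: compound 4 is estimated to show a 1.4-fold higher number from compound 3 to compound 4 (0.15 log units; within the scatter) relative to compound 3. That expectation rests on a single prior pair, so the range allowed around it is kept wide. Compound 4 is therefore expected to give about 5000 nM in this assay, with the estimate running from 2800 nM to 9000 nM.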

Compound 4, concentration for 50% growth inhibition: 3790 nM
Compound 4: middle estimate off by 1.3-fold (0.12 log units), on the high side, within the range that was stated.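

In this assay, putting 6-methylpyridin-3-yl in place of 2-chloropyridin-3-yl on the carbonyl carbon gave a 1.1-fold higher number from compound 3 to compound 4 (0.02 log units; within the scatter). Set beside the earlier instance of the same change, this step does not differ from it beyond what repeated measurements allow: the same change on two cores in this assay, a 1.4-fold higher number (0.15 log units; within the scatter) from compound 1 to compound 2 and a 1.1-fold higher number (0.02 log units; within the scatter) from compound 3 to compound 4, 1.3-fold (0.12 log units) apart, within the scatter of two such steps. This shows that the change stayed within the scatter on both the core of compound 1 and the core of compound 3, with no sign that the core altered its outcome, but it does not show that the change is without any effect or that it would behave the same way on a further core, as each step rests on a single pair of compounds and a small real effect could lie hidden within the scatter.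

The compounds shown leave open whether the group on the carbonyl carbon matters at all in this series, as only the 2-chloropyridin-3-yl and 6-methylpyridin-3-yl groups appear there. A phenyl ring, a morpholine or a longer alkyl chain at that place could show whether the number can move beyond the scatter.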